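Sugar swap on the shared core of compound 1

The compounds below may be only part of what the source reports. "The series", "measured", "known", "first", "only" and "open" are said of these compounds alone.

Compound 1, `C[C@@H]1O[C@@H](n2c3ccccc3c3c4c(c5c6ccccc6ccc5c32)C(=O)NC4=O)[C@H](O)[C@H](O)[C@H]1O`, carries a six-membered sugar on an aromatic nitrogen of the shared core. In a functional assay on HCT-116 cells (Homo sapiens) for cytotoxicity (on this read-out lower numbers stand for stronger inhibition and higher numbers for weaker inhibition), compound 1 gives 3100 nM. Compound 2, `O=C1NC(=O)c2c1c1c3ccccc3ccc1c1c2c2ccccc2n1[C@H]1OC[C@@H](O)[C@@H](O)[C@H]1O`, gives 6000 nM, and compound 3, `O=C1NC(=O)c2c1c1c3ccccc3ccc1c1c2c2ccccc2n1[C@@H]1O[C@H](CO)[C@@H](O)[C@H]1O`, gives 3800 nM. The step of a 1.9-fold higher number from compound 1 to compound 2 (0.29 log units; within the scatter) and the step of a 1.2-fold higher number from compound 1 to compound 3 (0.09 log units; within the scatter) both stay within the scatter, as does a 1.6-fold lower number from compound 2 to compound 3 (0.20 log units; within the scatter), so changing the sugar among these three compounds moves the number little. Compound 4, `O=C1NC(=O)c2c1c1c3ccccc3ccc1c1c2c2ccccc2n1[C@H]1C[C@H](O)[C@@H](CO)O1`, changes the sugar again: 4-hydroxy-5-(hydroxymethyl)oxolan-2-yl in place of 3,4,5-trihydroxy-6-methyloxan-2-yl on an aromatic nitrogen. Because a 1.2-fold higher number from compound 1 to compound 3 (0.09 log units; within the scatter) and the other two measured sugar changes all lie within the scatter, compound 4 is expected to give a step of a 1.3-fold higher number from compound 1 to compound 4 (0.11 log units; within the scatter), not beyond the scatter. The value of compound 4 is estimated at 4000 nM, between 1500 nM and 12000 nM.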

Compound 4, half-maximal inhibitory concentration: 8700 nM
Compound 4: the middle estimate sits 2.2-fold (0.34 log units) below what was measured, within the range that was stated.
By their numbers in this assay, from the lowest: compounds 1, 3, 2 and 4 (each within the scatter of the next, the first and the last beyond it).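

Changing the sugar on this aromatic nitrogen can move the number beyond the scatter after all, though only modestly (a 2.8-fold higher number from compound 1 to compound 4 (0.45 log units; beyond the scatter)). The cleanest comparison changes one thing, hydrogen in place of hydroxy on a saturated ring carbon, and that alone also goes beyond the scatter (a 2.3-fold higher number from compound 3 to compound 4 (0.36 log units; beyond the scatter)). The six-membered sugar of compound 2 goes against a simple sugar-based trend, since its step stays within the scatter (a 1.5-fold higher number from compound 2 to compound 4 (0.16 log units; within the scatter)).

Nothing available explains the loss seen with this hydroxy. As far as these compounds go, whether an amine or a fluorine at that ring carbon would behave like the hydroxy or like hydrogen stays open.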